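2-Fluorophenyl to 2-methoxyphenyl on the shared core

The source may report more compounds than this note shows. Statements on the series, on what has been measured and on what is new or still open speak of the compounds shown alone.

Three compounds share one core: compound 1 (`COC(=O)CC/C(C)=C/Cc1c(OC)c(C)c2c(c1OCC#CCN1CCN(C(c3ccc(F)cc3)c3ccc(F)cc3)CC1)C(=O)OC2`), compound 2 (`COC(=O)CC/C(C)=C/Cc1c(OC)c(C)c2c(c1OCC#CCN1CCN(c3ccccc3F)CC1)C(=O)OC2`) and compound 3 (`COC(=O)CC/C(C)=C/Cc1c(OC)c(C)c2c(c1OCC#CCN1CCN(C(c3ccccc3)c3ccc(Cl)cc3)CC1)C(=O)OC2`). In a functional assay on HT-29 cells (Homo sapiens) for inhibition, read by sulforhodamine B assay (on this read-out lower numbers stand for stronger inhibition and higher numbers for weaker inhibition), compound 1 gives > 50000 nM as a limit and not a number. Compound 2 gives > 50000 nM in this assay as a limit as well. Compound 3 gives > 50000 nM again as a limit. Compound 2 therefore has no numerical value, and the limit of > 50000 nM in this assay, at which 3 of the 3 values shown sit, describes the whole series. Compound 4 (`COC(=O)CC/C(C)=C/Cc1c(OC)c(C)c2c(c1OCC#CCN1CCN(c3ccccc3OC)CC1)C(=O)OC2`) carries methoxy in place of fluoro on an aromatic carbon, ortho to a large group. For the measured compounds named here, no measured step is available to size this change. The expected step of a number no higher from compound 2 to compound 4 (the limit leaves the size open) is none beyond the scatter in this assay and is likely to end at the same limit. For compound 4 the estimate is 50000 nM with an expected range from 25000 nM to 100000 nM in this series.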

Compound 4, half-maximal inhibitory concentration: > 50000 nM
Compound 4: only a limit was reported (the forecaster's own chance of this, stated with the estimate: 85%); the middle value sits exactly at the limit.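

No step can be read from compound 2 to compound 4, as both results are limits and not numbers: the limit of > 50000 nM in this assay, at which 4 of the 4 values shown sit.

The compounds shown leave open how the four rank against one another, and whether methoxy in place of fluoro changes inhibition at all.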